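The source may report more compounds than this note shows. Statements on the series, on what has been measured and on what is new or still open speak of the compounds shown alone.

Values in a functional assay on HMEC-1 cells (Homo sapiens) for antiproliferative activity, read by cell counting, with a stated time of 4 days; on this read-out higher numbers stand for weaker inhibition and lower numbers for stronger inhibition:
- compound 1 `CC(=O)c1ccc(Oc2ccccc2NC(C)=C2C(=O)CC(c3ccccc3)CC2=O)cc1` gives 180 nM
- compound 2 `COc1ccc(Oc2ccccc2NC(C)=C2C(=O)CC(c3ccccc3)CC2=O)cc1OC` gives 140 nM
- compound 3 `CC(Nc1ccccc1Oc1ccccc1)=C1C(=O)CC(c2ccccc2)CC1=O` gives 160 nM

These three cannot be told apart: a 1.1-fold lower number from compound 1 to compound 3 (0.05 log units; within the scatter), a 1.1-fold higher number from compound 2 to compound 3 (0.06 log units; within the scatter) and a 1.3-fold lower number from compound 1 to compound 2 (0.11 log units; within the scatter) all lie within the scatter, so compound 3 stands level with the other two. Compound 4 `CC(Nc1ccccc1Oc1ccc(N)cc1)=C1C(=O)CC(c2ccccc2)CC1=O` differs from compound 3 by one change, (amino in place of hydrogen on an aromatic carbon), which turns phenoxy into 4-aminophenoxy. The two steps ending at compound 3 bear on it most directly, as both alter the same phenyl, and neither exceeds the scatter. Amino itself has not been measured, so the expectation rests on those small steps alone. The expected step is a 1.1-fold lower number from compound 3 to compound 4 (0.03 log units; within the scatter), with no direction expected beyond the scatter. For compound 4 the estimated value is 150 nM, with an expected range of 70 nM to 330 nM.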

Compound 4, half-maximal inhibitory concentration: 47 nM
Beside the measured number, compound 4's estimate is 3.2-fold (0.50 log units) above it; measured number outside the range, below it.
By their numbers in this assay, from the lowest: compound 4; then compounds 2, 3 and 1 (each within the scatter of the next).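

In this assay the place para to a large group turns out to respond: amino in place of hydrogen gives a 3.4-fold lower number from compound 3 to compound 4 (0.53 log units; beyond the scatter) and so goes beyond the scatter, unlike the earlier changes on this ring. The other two compounds fall short in the same way, with a 3.0-fold lower number from compound 2 to compound 4 (0.47 log units; beyond the scatter) and a 3.8-fold lower number from compound 1 to compound 4 (0.58 log units; beyond the scatter) as the steps, so compound 4 is the most potent of the four. Nothing at hand explains this. The compounds shown leave open whether a methylamino, dimethylamino or hydroxyl group would do the same here. They also leave open how amino would fare elsewhere on this ring.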